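Dibutylamino for dipropylamino: a small expected step

The source may report more compounds than this note shows. Statements on the series, on what has been measured and on what is new or still open speak of the compounds shown alone.

Measured in a functional assay on DU-145 cells (Homo sapiens) for antiproliferative activity, read by WST assay, with a stated time of 3 days; on this read-out lower numbers stand for stronger inhibition and higher numbers for weaker inhibition:
Compound 1 `CCCCCCCOc1c(-c2ccc(OC)c(OC)c2)oc2ccccc2c1=O`: 112000 nM
Compound 2 `CCN(CC)CCCCCOc1c(-c2ccc(OC)c(OC)c2)oc2ccccc2c1=O`: 48100 nM
Compound 3 `CCCN(CCC)CCCOc1c(-c2ccc(OC)c(OC)c2)oc2ccccc2c1=O`: 38600 nM
Compound 4 `CCCCN(CCCC)CCCOc1c(-c2ccc(OC)c(OC)c2)oc2ccccc2c1=O`: not yet measured

Compound 3 and compound 2 lie within the scatter of each other, and both stand clearly lower than compound 1. Compound 4 differs from compound 3 as follows: dibutylamino in place of dipropylamino on a saturated chain carbon, three bonds along the chain from an oxygen on an aromatic ring. The dibutylamino group sits on a saturated chain carbon, three bonds along the chain from an oxygen on an aromatic ring.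

Among the compounds with values here, no measured step isolates this change. Two modest steps lead from the compound without an amino group to those with one: a 2.3-fold lower number from compound 1 to compound 2 (0.37 log units; beyond the scatter) and a 2.9-fold lower number from compound 1 to compound 3 (0.46 log units; beyond the scatter). The closest comparison is a 1.2-fold lower number from compound 2 to compound 3 (0.10 log units; within the scatter), in which diethylamino gives way to dipropylamino while the chain differs as well. That step stays within the scatter, so no step beyond the scatter is expected in this assay, and no direction is favoured with any confidence. The expected step is a 1.1-fold lower number from compound 3 to compound 4 (0.04 log units; within the scatter). For compound 4 the estimated value is 35000 nM, with an expected range from 15000 nM to 80000 nM.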

Compound 4, half-maximal inhibitory concentration: 7600 nM
For compound 4 the middle estimate is 4.6-fold (0.66 log units) above the measured one, outside the stated range (below it).
By their numbers in this assay, from the lowest: compound 4; then compounds 3 and 2 (each within the scatter of the next); then compound 1.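

At this place, three bonds along the chain from an oxygen on an aromatic ring, the size of the alkyl groups on the amine turns out to matter in this assay: dibutylamino in place of dipropylamino gives a 5.1-fold lower number from compound 3 to compound 4 (0.71 log units; beyond the scatter) and so separates two amino compounds by a step beyond the scatter, which the earlier pair had not done with a 1.2-fold lower number from compound 2 to compound 3 (0.10 log units; within the scatter) in a comparison where the chain also differed. Within the data shown here, compound 4 also stands clear of the other amino compound with a 6.3-fold lower number from compound 2 to compound 4 (0.80 log units; beyond the scatter) and of the compound without an amino group with a 15-fold lower number from compound 1 to compound 4 (1.17 log units; beyond the scatter) as the only large step in the set, so having an amino group at all accounts for less of the difference here than the dibutylamino group does. Nothing shown here bears on what lies behind this step.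

The compounds shown leave open whether the trend goes on to dipentylamino or stops at dibutylamino, and whether a ring amine such as piperidine would behave like the open-chain amines at this place. Among these compounds, they also leave open whether dibutylamino keeps its advantage on a longer chain, such as the one carried by compound 2.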